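Working notes: amino to methylamino on compound 2

This account rests on a few compounds, and the source may have more. Where it says the series, first, only, none or still open, it means among the compounds named here.

compound 1 `CCc1ccc(Cl)cc1-n1cc(-c2ncnn3cccc23)cc1C(N)=O` gives 3070 ng.h/mL
compound 2 `CCc1ccc(Cl)cc1-n1cc(-c2cc(N)ncn2)cc1C(N)=O` gives 16800 ng.h/mL
compound 3 `Cc1ccc(Cl)cc1-c1cn(-c2ncnc3[nH]ccc23)cc1C(N)=O` gives "not determined" (no result reported)

Within the data shown here, only two compounds carry a number so far. In an ADME assay on the whole organism (plasma, strain Balb) for pharmacokinetics, with Mus musculus as the target, read by LC-MS, at a dose of 10 mg/kg by the intravenous route (a higher number here means more compound in the circulation at the dose given, a lower number less compound in the circulation), compound 2 stands highest at 16800 ng.h/mL and compound 1 lies lower at 3070 ng.h/mL by a gap beyond the scatter, while compound 3 adds no number.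

The next compound is compound 4 `CCc1ccc(Cl)cc1-n1cc(-c2cc(NC)ncn2)cc1C(N)=O` which turns the 6-aminopyrimidin-4-yl group of compound 2 into 6-(methylamino)pyrimidin-4-yl. The change is methyl in place of hydrogen on a nitrogen on an aromatic ring and reads as methyl in place of hydrogen on a nitrogen on an aromatic ring. Among the measured compounds shown here, no measured pair shows a step of this kind, so the expectation has little support and the range stays wide. A modest fall in this assay is expected, of a size that may not clear the scatter. The estimate means a 1.7-fold lower number from compound 2 to compound 4 (0.23 log units; within the scatter) as the expected step. Compound 4 is expected at 10000 ng.h/mL with a range of 3500 ng.h/mL to 25000 ng.h/mL around that estimate.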

Compound 4, area under the concentration-time curve in the Mus musculus assay: 13300 ng.h/mL
Estimate against measurement, compound 4: 1.3-fold (0.12 log units) below, within the range that was stated.
By their numbers in the Mus musculus assay, from the lowest: compound 1; then compounds 4 and 2 (each within the scatter of the next).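

In the Mus musculus assay, compound 2 gives 16800 ng.h/mL and compound 4 gives 13300 ng.h/mL, and methyl in place of hydrogen on a nitrogen on an aromatic ring gives a 1.3-fold lower number from compound 2 to compound 4 (0.10 log units; within the scatter), the only step of this kind shown, so amino and methylamino cannot be told apart at this position in the circulation read-out. In a physicochemical assay for solubility, at pH 7 (a lower number here means a less soluble compound, a higher number a more soluble compound), compound 2 gives 128000 nM and compound 4 gives 111000 nM, and the same change gives a 1.2-fold lower number from compound 2 to compound 4 (0.06 log units; within the scatter), so this read-out does not separate the pair either. No measurement at hand bears on why the two compounds stay this close.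

This is one step on one core, and it leaves open whether a longer chain on this nitrogen, such as ethyl, or a second methyl as in dimethylamino, would also stay within the scatter. On these data alone, whether the same methyl would give a similar step on the core of compound 1 also stays open.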